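The source may report more compounds than this note shows. Statements on the series, on what has been measured and on what is new or still open speak of the compounds shown alone.

Of the compounds shown here, two of a shared core have been measured in a functional assay on cardiac atrium for agonist activity at histamine H2 receptor (Cavia porcellus); a lower number here means that less compound is needed, a higher number that more compound is needed for the effect. Compound 1 `N=C(NCCCc1c[nH]cn1)NC(=O)CC(c1ccccc1)c1ccc(F)cc1` gives 55 nM, the lowest of the two numbers. Compound 2 `N=C(NCCCc1c[nH]cn1)NC(=O)CC(c1ccc(Cl)cc1)c1ccc(Cl)cc1` gives 309 nM, and that is a gap from compound 1 that lies beyond the usual scatter of this assay. Compound 3 `N=C(NCCCc1c[nH]cn1)NC(=O)CC(c1ccccc1)c1nccs1` has not yet been measured. It differs from compound 1 in a single place: 1,3-thiazol-2-yl in place of 4-fluorophenyl on a saturated chain carbon bound to an aromatic carbon and a saturated chain carbon. Among the measured compounds shown here, since compound 2 changes two groups at once, nothing measured so far tells how this single exchange shifts the number, so any expectation rests on compound 1 alone. The step from compound 1 to compound 3 is estimated to be small, a modest rise in the number that may sit near or just past the scatter, expressed as a 2.2-fold higher number from compound 1 to compound 3 (0.34 log units; beyond the scatter). Compound 3 is therefore expected to give about 120 nM in this assay, with a range from 30 nM to 500 nM.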

Compound 3, half-maximal effective concentration: 38 nM
Beside the measured number, compound 3's estimate is 3.2-fold (0.50 log units) above it, within the range that was stated.
By their numbers in this assay, from the lowest: compounds 3 and 1 (each within the scatter of the next); then compound 2.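

In this assay, putting 1,3-thiazol-2-yl in place of 4-fluorophenyl gives a 1.4-fold lower number from compound 1 to compound 3 (0.16 log units; within the scatter), so this single exchange leaves the number unmoved beyond the scatter. At this position, on a saturated chain carbon bound to an aromatic carbon and a saturated chain carbon, a five-membered aromatic ring with 2 hetero atoms and 2 hydrogen-bond acceptors thus serves about as well as a six-membered carbon ring carrying fluorine. Nothing available here explains why the two groups give such similar numbers.

On these data alone, whether this position needs an aromatic ring at all remains open, and a saturated ring such as cyclohexyl or a small group such as methyl would test that. As far as these compounds go, it is also open whether an amine or a carboxylic acid on the ring would be accepted here.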